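A few compounds are considered here, and "the series" means these few. Any claim that something is new, unique, unknown or untested is made for them only; others in the source may bear on it.

Measured compounds in an ADME assay on cells (Hepatocyte, Mus musculus) for metabolic stability, with a stated time of 30 min; on this read-out higher numbers stand for a more stable compound and lower numbers for a less stable compound:
Compound 1, `O=C(OC1CCC(CN2CCN(c3cc(=O)c4cc(C(F)(F)F)cc([N+](=O)[O-])c4s3)CC2)CC1)C1CCCCC1`, gives 1.2%.
Compound 2, `O=C(OC1CCC(CN2CCN(c3cc(=O)c4cc(C(F)(F)F)cc([N+](=O)[O-])c4s3)CC2)CC1)c1cccs1`, gives 1.8%.
Compound 3, `COc1ccc(C(=O)OC2CCC(CN3CCN(c4cc(=O)c5cc(C(F)(F)F)cc([N+](=O)[O-])c5s4)CC3)CC2)cc1`, gives 31%.

Compound 3 stands highest of the three in this assay: the steps of a number 29.8 percentage points higher from compound 1 to compound 3 (beyond the scatter) and a number 29.2 percentage points higher from compound 2 to compound 3 (beyond the scatter) both lie beyond the scatter, whereas a number 0.6 percentage points higher from compound 1 to compound 2 (within the scatter) stays within it. Compound 4, `O=C(OC1CCC(CN2CCN(c3cc(=O)c4cc(C(F)(F)F)cc([N+](=O)[O-])c4s3)CC2)CC1)c1ccccc1`, differs from compound 3 in one place: hydrogen in place of methoxy on an aromatic carbon. Going by the values given here, no measured step removes this group. The two steps that reach compound 3 exchange the whole group on the carbonyl carbon, from cyclohexyl and from thiophen-2-yl to 4-methoxyphenyl, and both are modest gains. They show that the group on the carbonyl carbon matters in this assay, but they do not separate the part played by the methoxy from that of the six-membered aromatic ring, and compound 2, which also carries an aromatic ring on the carbonyl carbon, gives only 1.8%. The step from compound 3 to compound 4 is therefore expected to be a loss, probably beyond the scatter but smaller than either measured gain, estimated as a number 16 percentage points lower from compound 3 to compound 4 (beyond the scatter). For compound 4 the estimate is 15%, with a range expected from 3% to 35%.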

Compound 4, percent of the compound remaining: 68.1%
Compound 4: middle estimate off by 53.1 percentage points, on the low side; the whole stated range lies below it.
By their numbers in this assay, from the lowest: compounds 1 and 2 (each within the scatter of the next); then compound 3; then compound 4.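

In this assay, going by these compounds alone, the change from 4-methoxyphenyl to phenyl gives a number 37.1 percentage points higher from compound 3 to compound 4 (beyond the scatter) and so reverses the reading of the earlier steps: the methoxy was not what lifted compound 3 above compounds 1 and 2, and with hydrogen at this place the number rises further. The exchanges of the whole group on the carbonyl carbon now give a number 66.3 percentage points higher from compound 2 to compound 4 (beyond the scatter) and a number 66.9 percentage points higher from compound 1 to compound 4 (beyond the scatter) as the largest steps in the set, which makes the unsubstituted phenyl the best group seen at this position and shows, through compound 2, that carrying some aromatic ring there is not enough to produce such a gain. Nothing in the data shown accounts for the size or the direction of these differences.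

The compounds shown leave open whether the loss seen with methoxy is particular to that group or would also appear with a smaller group at the same place on the phenyl ring, such as fluorine or methyl. They also leave open how a pyridine ring on the carbonyl carbon would compare with the phenyl of compound 4.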